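A few compounds are considered here, and "the series" means these few. Any claim that something is new, unique, unknown or untested is made for them only; others in the source may bear on it.

Compound 1, with the structure `COc1cc2c(Oc3ccc(NC(=O)c4nn(-c5ccccc5OC(F)(F)F)c(=O)cc4C)cc3F)ccnc2cc1OCCCN1CCCC1`, is the starting point. In a functional assay on A549 cells (Homo sapiens) for inhibition, read by MTT assay, with a stated time of 72 h (on this read-out higher numbers stand for weaker inhibition and lower numbers for stronger inhibition), compound 1 gives 140 nM. Compound 2, with the structure `COc1cc2c(Oc3ccc(NC(=O)c4nn(-c5ccccc5OC(F)(F)F)c(=O)cc4C)cc3F)ccnc2cc1OCCCN1CCCCC1`, differs from it by one change: piperidin-1-yl in place of pyrrolidin-1-yl on a saturated chain carbon, three bonds along the chain from an oxygen on an aromatic ring. That change gave a 1.2-fold lower number from compound 1 to compound 2 (0.07 log units; within the scatter), and compound 2 gives 120 nM in this assay.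

Compound 3, with the structure `COc1cc2c(Oc3ccc(NC(=O)c4nn(-c5ccc(Cl)cc5)c(=O)cc4C)cc3F)ccnc2cc1OCCCN1CCCC1`, shares most of its structure with compound 1, but its core differs in one place: 4-chlorophenyl in place of 2-(trifluoromethoxy)phenyl on an aromatic nitrogen. Between these two the difference was a 1.6-fold higher number from compound 1 to compound 3 (0.22 log units; within the scatter), so that in this assay compound 3 gives 230 nM. Among the three measured compounds this is the highest number, though its gaps to the other two both sit within the usual scatter of repeated measurements.

Compound 4, with the structure `COc1cc2c(Oc3ccc(NC(=O)c4nn(-c5ccc(Cl)cc5)c(=O)cc4C)cc3F)ccnc2cc1OCCCN1CCCCC1`, has not yet been measured. It carries the core of compound 3 and is reached from it by the change (piperidin-1-yl in place of pyrrolidin-1-yl on a saturated chain carbon, three bonds along the chain from an oxygen on an aromatic ring). This is the same change that turns compound 1 into compound 2, made at the same place, so the step already seen is the best guide. From compound 3 to compound 4 the expected step in this assay is a 1.2-fold lower number from compound 3 to compound 4 (0.06 log units; within the scatter), which rests on compound 1 and compound 2 having shown a 1.2-fold lower number from compound 1 to compound 2 (0.07 log units; within the scatter). On that basis compound 4 is estimated to give 200 nM in this assay, with a plausible range from 100 nM to 400 nM.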

Compound 4, half-maximal inhibitory concentration: 320 nM
Beside the measured number, compound 4's estimate is 1.6-fold (0.20 log units) below it; the measured number falls inside the stated range.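

In this assay, piperidin-1-yl in place of pyrrolidin-1-yl gave a 1.4-fold higher number from compound 3 to compound 4 (0.14 log units; within the scatter), and this step does not differ measurably from the one seen earlier: the same change on two cores in this assay, a 1.2-fold lower number (0.07 log units; within the scatter) from compound 1 to compound 2 and a 1.4-fold higher number (0.14 log units; within the scatter) from compound 3 to compound 4, 1.6-fold (0.21 log units) apart, within the scatter of two such steps. The other change, 4-chlorophenyl in place of 2-(trifluoromethoxy)phenyl on an aromatic nitrogen, gave a 2.7-fold higher number from compound 2 to compound 4 (0.43 log units; beyond the scatter), a modest step beyond the scatter, yet it also agrees with its earlier counterpart, which was itself within the scatter: the same change on two cores in this assay, a 1.6-fold higher number (0.22 log units; within the scatter) from compound 1 to compound 3 and a 2.7-fold higher number (0.43 log units; beyond the scatter) from compound 2 to compound 4, 1.6-fold (0.21 log units) apart, within the scatter of two such steps. So, within these four compounds, neither change shows a dependence on the core it is made on, but this rests on just two cores per change and does not prove that the steps are identical, nor does it show that the swap of the two amine rings has any real effect in this assay.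

The compounds shown leave open whether the same agreement would hold for other amines at the end of the chain, such as morpholine or dimethylamine, or for a shorter or longer chain than 3-(pyrrolidin-1-yl)propyl. They also leave open how a plain phenyl, a 4-fluorophenyl or a 4-(trifluoromethoxy)phenyl on the aromatic nitrogen would compare, which would help separate the effect of the group from that of its place on the ring.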